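Diphenylmethyl sulfoxides: a heteroaryl swap at the methylene

The source may report more compounds than this note shows. Statements on the series, on what has been measured and on what is new or still open speak of the compounds shown alone.

The series shares a core seen in compound 1 `[O-][S+](Cc1ccc(Cl)s1)C(c1ccccc1)c1ccccc1`; in an assay on HEK293 cells for inhibition of sodium-dependent dopamine transporter (Homo sapiens), read by scintillation counting, with stated times of 5 min and 1 min (a lower number here means a stronger inhibitor, a higher number a weaker inhibitor), compound 1 gives 12800 nM. Compound 2 `[O-][S+](Cc1cccs1)C(c1ccc(Cl)cc1)c1ccc(Cl)cc1` gives 7200 nM in this assay, a number within the scatter of compound 1. Compound 3 `[O-][S+](Cc1nc(C(F)(F)F)no1)C(c1ccccc1)c1ccccc1` gives 43700 nM, a higher number beyond the scatter. Compound 1 thus stands second highest of the three numbers.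

Compound 4 `[O-][S+](Cc1cc(C2CC2)on1)C(c1ccccc1)c1ccccc1` carries the change (5-cyclopropyl-1,2-oxazol-3-yl in place of 5-chlorothiophen-2-yl on a saturated chain carbon bound to a sulfur). Among the measured compounds shown here, no step between measured compounds covers this change; the only other heteroaryl swap seen, compound 3 against compound 1, runs toward a higher number. A step of a 2.0-fold higher number from compound 1 to compound 4 (0.29 log units; within the scatter) toward a weaker inhibitor is therefore expected for compound 4. In this assay compound 4 is estimated at 25000 nM, with a range of 10000 nM to 60000 nM.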

Compound 4, half-maximal inhibitory concentration: 38600 nM
For compound 4 the middle estimate is 1.5-fold (0.19 log units) below the measured one; the range from low to high includes it.
By their numbers in this assay, from the lowest: compounds 2 and 1 (each within the scatter of the next); then compounds 4 and 3 (each within the scatter of the next).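

In this assay the place on a saturated chain carbon bound to a sulfur does respond to the ring carried there: 5-cyclopropyl-1,2-oxazol-3-yl in place of 5-chlorothiophen-2-yl gives a 3.0-fold higher number from compound 1 to compound 4 (0.48 log units; beyond the scatter) as a modest step toward a weaker inhibitor. Compound 4 at 38600 nM and compound 3 at 43700 nM lie within the scatter of each other, so both swaps away from compound 1 end at similar numbers. No supporting measurement bears on this step.

Open, as far as these compounds go, is whether the chlorine or the thiophene ring matters more in compound 1. From the compounds shown here alone, how a phenyl ring or a piperidine would read at this place also remains unknown.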